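Compound 1 at its limit, and what compound 4 may do

The compounds below may be only part of what the source reports. "The series", "measured", "known", "first", "only" and "open" are said of these compounds alone.

In an ADME assay on microsomes from liver (Homo sapiens) for metabolic stability (a higher number here means that the compound lasts longer, a lower number that the compound disappears faster), compound 1 (`CC(C)C(/C=C1\NC(=O)NC1=O)c1ccc(-c2ccc3cccc(F)c3c2)[nH]c1=O`) gives > 3 h, which is a limit and not a number. Two relatives give actual numbers. Compound 3 (`O=C1NC(=O)/C(=C/C(c2ccc(-c3ccc4cccc(F)c4c3)[nH]c2=O)C2CC2)O1`) gives 1.98 h. Compound 2 (`CCc1cccc2ccc(-c3ccc(C(/C=C4\OC(=O)NC4=O)(CC)CC)c(=O)[nH]3)cc12`) gives 0.178 h. Both differ from compound 1 in more than one place, so neither offers a clean comparison of a single change.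

Compound 4 (`CC(C)C(CC1NC(=O)NC1=O)c1ccc(-c2ccc3cccc(F)c3c2)[nH]c1=O`) keeps the core of compound 1 and changes one group: a group of 8 heavy atoms (4 carbon, 2 nitrogen, 2 oxygen; one five-membered non-aromatic ring with 2 hetero atoms) in place of a group of 8 heavy atoms (4 carbon, 2 nitrogen, 2 oxygen; one five-membered non-aromatic ring with 2 hetero atoms), on a saturated chain carbon bound to an aromatic carbon and a saturated chain carbon. For the measured compounds named here, no pair of measured compounds here shows what this kind of exchange does, so any forecast is uncertain. Compound 1 also has no exact half-life to start from, and compound 4 may likewise return only a limit. No step beyond the usual scatter is expected in this assay. The estimate amounts to an at least 1.0-fold lower number from compound 1 to compound 4 (0.02 log units; that floor lies within the scatter), a small expected move towards faster disappearance at most. The lower end of the range is set with compound 3 in mind, which gives 1.98 h. For compound 4 the expected half-life is 2.8 h, with an estimated range from 1 h to 7 h.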

Compound 4, half-life: 1.59 h
For compound 4 the middle estimate is 1.8-fold (0.25 log units) above the measured one, and the stated range covers the measured number.
By their numbers in this assay, from the lowest: compound 2; then compounds 4 and 3 (each within the scatter of the next). At a limit, above all of these: compound 1.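

For the compounds shown here, compound 4 carries (2,5-dioxoimidazolidin-4-yl)methyl on the saturated chain carbon bound to an aromatic carbon and a saturated chain carbon, and this exchange gives an at least 1.8-fold lower number from compound 1 to compound 4 (0.27 log units; that floor lies within the scatter); this is the first step that can be read at this position, and the two groups match in heavy atoms, ring, hydrogen-bond donors and hydrogen-bond acceptors, while the count of double bonds outside aromatic rings goes from 3 to 2. In this assay compound 1 gives > 3 h, which is a limit and not a number. The step is therefore only a floor, and the real drop could be larger, because the starting point is a limit: the limit of > 3 h in this assay, at which 1 of the 4 values shown sits.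

The compounds shown leave open how the half-life responds to a different kind of group at this place, such as a carboxylic acid, an amine or a longer chain in place of (2,5-dioxoimidazolidin-4-yl)methyl. They also leave open whether the same exchange would have a comparable effect when made on compound 2 or compound 3, and how large the step from compound 1 really is.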